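Hydroxy added to the azole ring of compound 3

The source may report more compounds than this note shows. Statements on the series, on what has been measured and on what is new or still open speak of the compounds shown alone.

Measured in an assay on HEK293 cells for binding affinity to 5-hydroxytryptamine receptor 7 (Homo sapiens), read by radioligand binding (on this read-out higher numbers stand for weaker inhibition and lower numbers for stronger inhibition), so far:
compound 1 `CC1CCN(CC[C@H]2CCCN2S(=O)(=O)c2ccc3c(c2)NCC3)CC1`: 22.9 nM
compound 2 `CC1CCN(CC[C@H]2CCCN2S(=O)(=O)c2ccc3c[nH]nc3c2)CC1`: 6.46 nM
compound 3 `CC1CCN(CC[C@H]2CCCN2S(=O)(=O)c2ccc3[nH]cnc3c2)CC1`: 6.46 nM

Compound 3 stands level with compound 2 at the digits shown, the two of them together at the lowest numbers of the three; against compound 1 it is lower by a margin beyond the scatter. Compound 4 `CC1CCN(CC[C@H]2CCCN2S(=O)(=O)c2ccc3[nH]c(O)nc3c2)CC1` differs from compound 3 in one place: hydroxy in place of hydrogen on an aromatic carbon, a hydroxy carrying one hydrogen-bond donor and one acceptor, set on the five-membered ring with two nitrogen between two ring nitrogen atoms. Among the compounds with values here, no measured pair shows this change, so the step is unanchored; the three cores so far span only a narrow range. The expected step from compound 3 to compound 4 is a 1.5-fold higher number from compound 3 to compound 4 (0.19 log units; within the scatter), a small rise or none beyond the scatter. Compound 4 is estimated at 10 nM in this assay, with a range from 3 nM to 35 nM.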

Compound 4, inhibition constant: 57.5 nM
The estimate for compound 4 lay 5.8-fold (0.76 log units) below the measured number, outside the stated range (above it).
By their numbers in this assay, from the lowest: compounds 2 and 3 (each within the scatter of the next); then compound 1; then compound 4.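

In this assay, within the data shown here, the aromatic carbon between two ring nitrogen atoms does not take hydroxy in place of hydrogen without cost: the change gives an 8.9-fold higher number from compound 3 to compound 4 (0.95 log units; beyond the scatter), the first single-place step and one beyond the scatter. This position therefore responds to substitution, at least with hydroxy. No measurement available here accounts for the rise.

On these data alone, whether a methyl or an amine on the same carbon would give a comparable step remains open. So does whether the rise follows hydroxy specifically or any group replacing hydrogen there.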